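The source may hold more compounds than are shown below. What is called first, only, known or untested is meant among the compounds shown, and "the series" means these compounds.

Series notes. Compound 1 `CC1=CSC2=NC(/C=C/c3ccccc3)=C(C(=O)/C=C/c3ccccc3)C(c3ccccc3)N12` is the parent of the set; in an ADME assay on Vero cells (Chlorocebus sabaeus) for cytotoxicity, read by fluorescence and resazurin assay, with a stated time of 72 h (a lower number here means that less compound is tolerated, a higher number that more compound is tolerated), compound 1 gives 195 ug/mL. Compound 3 `CC1=CSC2=NC(/C=C/c3ccccc3)=C(C(=O)/C=C/c3ccccc3)C(c3ccc(Cl)cc3)N12` carries one change from compound 1, (chloro in place of hydrogen on an aromatic carbon), and in this assay compound 3 gives 320 ug/mL; the step is a 1.6-fold higher number from compound 1 to compound 3 (0.22 log units; within the scatter). Compound 2 `CC1=CSC2=NC(/C=C/c3cccc(Cl)c3)=C(C(=O)/C=C/c3cccc(Cl)c3)C(c3ccccc3)N12` has a core that differs from the core of compound 1 in a way that is not broken down here; in this assay compound 2 gives 286 ug/mL. Against compound 3 and against compound 1, compound 2 sits within the scatter in both cases. Compound 4 `CC1=CSC2=NC(/C=C/c3cccc(Cl)c3)=C(C(=O)/C=C/c3cccc(Cl)c3)C(c3ccc(Cl)cc3)N12` is not yet measured. Its relation to compound 2 is chloro in place of hydrogen on an aromatic carbon, the same change as that from compound 1 to compound 3, at the same place in both pairs. The step from compound 2 to compound 4 in this assay is expected to be a 1.2-fold higher number from compound 2 to compound 4 (0.09 log units; within the scatter), resting on a 1.6-fold higher number from compound 1 to compound 3 (0.22 log units; within the scatter), a step within the scatter, so no clear movement is expected. Compound 4 is expected to give about 350 ug/mL, with a range from 200 ug/mL to 600 ug/mL.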

Compound 4, half-maximal cytotoxic concentration: 317 ug/mL
The estimate for compound 4 lay 1.1-fold (0.04 log units) above the measured number, within the range that was stated.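

In this assay the chloro in place of hydrogen on an aromatic carbon, read one bond further out as phenyl to 4-chlorophenyl, gives a 1.1-fold higher number from compound 2 to compound 4 (0.04 log units; within the scatter). Set beside the earlier step, the two readings of this change cannot be told apart: the same change on two cores in this assay, a 1.6-fold higher number (0.22 log units; within the scatter) from compound 1 to compound 3 and a 1.1-fold higher number (0.04 log units; within the scatter) from compound 2 to compound 4, 1.5-fold (0.17 log units) apart, within the scatter of two such steps This gives no sign that the core of compound 2 reads the change differently from the core of compound 1, but with both steps inside the scatter it does not show that the change moves the number on either core, nor that the two steps are truly equal, and two pairs make no rule for the series.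

Still open, as far as these compounds go, is how an amine, a carboxylic acid or a longer chain would read in place of chloro at this position, and whether any such group would give a step beyond the scatter. Also open, from the compounds shown here alone, is whether the change carries across further cores.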